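The compounds below may be only part of what the source reports. "The series", "measured", "known", "first", "only" and "open" are said of these compounds alone.

Working notes on the series. Compound 1 `N#Cc1cnc(NCc2cnccc2C(F)(F)F)cc1N[C@H]1C[C@@H](O)C1` gives only a limit in an assay on isolated protein for inhibition of protein kinase C delta type (Homo sapiens), read by TR-FRET, with a stated time of 2 h (a higher number here means a weaker inhibitor, a lower number a stronger inhibitor), namely > 10000 nM. Compound 2 `N#Cc1cnc(NCc2cnccc2C(F)(F)F)cc1NC[C@H]1CC[C@H](O)CC1` gives 2000 nM in this assay. Compound 3 `CO[C@H]1CC[C@@H](CNc2cc(NCc3cnccc3C(F)(F)F)ncc2C#N)CC1` gives 5000 nM, the higher of the two numbers, and the step of a 2.5-fold higher number from compound 2 to compound 3 (0.40 log units; beyond the scatter) is modest. Compound 4 `N#Cc1cnc(NCc2cnccc2C(F)(F)F)cc1N[C@H]1CC[C@@H](C(N)=O)CC1` is the next candidate; the change is 4-carbamoylcyclohexyl in place of (4-methoxycyclohexyl)methyl on a nitrogen on an aromatic ring. Going by the values given here, two measured steps bear on it: an at least 5.0-fold lower number from compound 1 to compound 2 (0.69 log units; beyond the scatter), where a hydroxylated ring set directly on the nitrogen is weaker than one carried by a methylene, and a 2.5-fold higher number from compound 2 to compound 3 (0.40 log units; beyond the scatter), where a terminal hydroxyl outperforms a methoxy. Compound 4 combines a directly attached ring with a donor-bearing terminus, so opposing pulls; the expected step is a 1.1-fold lower number from compound 3 to compound 4 (0.05 log units; within the scatter), within the scatter. Compound 4 is therefore estimated at 4500 nM, with a range of 1500 nM to 15000 nM.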

Compound 4, half-maximal inhibitory concentration: 400 nM
Compound 4: the middle estimate sits 11-fold (1.05 log units) above what was measured; measured number outside the range, below it.
By their numbers in this assay, from the lowest: compound 4; then compound 2; then compound 3. At a limit, above all of these: compound 1.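

In this assay, 4-carbamoylcyclohexyl on a nitrogen on an aromatic ring gives the lowest number of the series, so a ring set directly on that nitrogen is not weak in itself, though compound 1 shows that it can be. The steps of a 13-fold lower number from compound 3 to compound 4 (1.10 log units; beyond the scatter) and a 5.0-fold lower number from compound 2 to compound 4 (0.70 log units; beyond the scatter) both put compound 4 ahead of the (4-substituted cyclohexyl)methyl compounds. Compound 1 stands at a limit, so an at least 25-fold lower number from compound 1 to compound 4 (1.39 log units; beyond the scatter) is only a floor: the limit of > 10000 nM in this assay, at which 1 of the 4 values shown sits.

Attachment and terminal group change together here, and the compounds shown do not separate them. From the compounds shown here alone, whether (4-carbamoylcyclohexyl)methyl or 4-carboxycyclohexyl on that nitrogen would keep the gain stays open.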